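Replacing nitro by methoxy on the phenyl of compound 3

This account rests on a few compounds, and the source may have more. Where it says the series, first, only, none or still open, it means among the compounds named here.

The shared core carries a phenyl ring whose substituent on the aromatic carbon para to a large group is varied. Compound 1 `Nc1sc(-c2ccccc2)c(-c2cccc(C(F)(F)F)c2)c1C(=O)c1ccccc1` has hydrogen there; in a functional assay on CHO-K1 cells for agonist activity at adenosine receptor A1 (Homo sapiens), read by GTPgammaS binding (a higher number here means that more compound is needed for the effect, a lower number that less compound is needed), compound 1 gives 2.3 uM. Compound 2 `CC(=O)c1ccc(-c2sc(N)c(C(=O)c3ccccc3)c2-c2cccc(C(F)(F)F)c2)cc1` carries acetyl; in this assay compound 2 reaches only the limit > 10 uM. Compound 3 `Nc1sc(-c2ccc([N+](=O)[O-])cc2)c(-c2cccc(C(F)(F)F)c2)c1C(=O)c1ccccc1` carries nitro, and in this assay compound 3 also stands at the limit > 10 uM. Compound 3 thus sits at the limit of > 10 uM in this assay, at which 2 of the 3 values shown sit, and the step that the two limits leave unreadable from compound 2 to compound 3 stays unreadable. The two readable steps, an at least 4.3-fold higher number from compound 1 to compound 2 (0.63 log units; beyond the scatter) and an at least 4.3-fold higher number from compound 1 to compound 3 (0.63 log units; beyond the scatter), both show that a substituent at this position raises the number beyond the scatter.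

Compound 4 `COc1ccc(-c2sc(N)c(C(=O)c3ccccc3)c2-c2cccc(C(F)(F)F)c2)cc1` differs from compound 3 by methoxy in place of nitro on an aromatic carbon. Going by the values given here, no measured pair covers methoxy here; the two steps from compound 1 bear on it only as a third substituent at the same position, and since compound 3 is a limit, the direction cannot be fixed. Compound 4 is therefore expected near 6 uM, within 1.5 uM to 20 uM. The step of an at least 1.6-fold lower number from compound 3 to compound 4 (0.22 log units; that floor lies within the scatter) is expected to be small or itself unreadable.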

Compound 4, concentration for half-maximal effect: > 10 uM
Compound 4: only a limit was reported; the forecaster's own chance of this, stated with the estimate: 45%; middle value at least 1.6-fold (0.22 log units) from the limit.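

Methoxy on this aromatic carbon gives an at least 4.3-fold higher number from compound 1 to compound 4 (0.63 log units; beyond the scatter) in this assay, so the rise seen with acetyl and nitro also appears with a third group, and none of the substituted compounds shown returns to the level of compound 1 at 2.3 uM. Compound 4 stands at a limit, > 10 uM. The steps among compound 2, compound 3 and compound 4 cannot be read, so no order among acetyl, nitro and methoxy can be given: the limit of > 10 uM in this assay, at which 3 of the 4 values shown sit.

Still open, going by these compounds, is whether any group at this place keeps the number near that of compound 1, for instance a fluorine atom, a methyl group, an amine or a carboxylic acid. Also open, on these data alone, is how far apart compound 2, compound 3 and compound 4 truly lie.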